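A few compounds are considered here, and "the series" means these few. Any claim that something is new, unique, unknown or untested is made for them only; others in the source may bear on it.

Among the compounds with values here, compound 1 `CCC(CC)c1ccc2c(NCCCNCc3cc(F)ccc3OC)ccnc2c1` is one of three compounds measured in a physicochemical assay for acid dissociation. In this assay compound 1 gives 9.47. Compound 2 `Fc1ccc(Cc2ccc3c(NCCCNCc4ccco4)ccnc3c2)cc1` gives 9.47 and compound 3 `CCC(CC)c1ccc2c(NCCCNCc3ccco3)ccnc2c1` gives 9.47, so compound 1 stands level with both of them at the digits shown. Compound 4 `COc1ccc(F)cc1CNCCCNc1ccnc2cc(CC(C)C)ccc12` has not yet been measured. It differs from compound 1 in one place: isobutyl in place of pentan-3-yl on an aromatic carbon. The step from compound 2 to compound 3 bears most directly on this, since it too swaps one group for another on an aromatic carbon of the shared core, and it brought no change at the digits printed from compound 2 to compound 3 (within the scatter). The step from compound 1 to compound 3, which alters a different part of the molecule, likewise brought no change at the digits printed from compound 1 to compound 3 (within the scatter). Neither step moved the read-out, so the expected step is no change at the digits printed from compound 1 to compound 4 (within the scatter), none beyond the scatter. Compound 4 is therefore estimated at 9.47, with a range from 9.2 to 9.75.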

Compound 4, acid dissociation constant: 9.47
The estimate for compound 4 equals the measured number at the digits printed, within the range that was stated.
By their numbers in this assay, from the lowest: compounds 1, 2, 3 and 4 (each within the scatter of the next).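

In this assay isobutyl in place of pentan-3-yl on an aromatic carbon gives no change at the digits printed from compound 1 to compound 4 (within the scatter) on the shared core. The earlier step at this position exchanged pentan-3-yl with 4-fluorobenzyl on compounds carrying furan-2-yl, whereas this one is read on compounds carrying 5-fluoro-2-methoxyphenyl at the other end of the chain. Going from 5 heavy atoms to 4 in this all-carbon group therefore leaves the read-out where it was, and the position has now been probed with three different groups on two versions of the molecule without any movement beyond the scatter.

These compounds leave open whether an amine or a carboxylic acid on this aromatic carbon would move the read-out. Nothing available explains why the number holds steady across these changes.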